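The source may report more compounds than this note shows. Statements on the series, on what has been measured and on what is new or still open speak of the compounds shown alone.

In an ADME assay on Vero cells (Chlorocebus sabaeus) for cytotoxicity, read by resazurin assay, with a stated time of 72 h (on this read-out lower numbers stand for stronger inhibition and higher numbers for weaker inhibition), compound 1 (`COc1ccc(C(=O)CCN2CCN(c3ccc(Cl)cc3)CC2)cc1`) gives 300000 nM and compound 2 (`O=C(CCN1CCN(c2ccc(Cl)cc2)CC1)c1ccc(Br)cc1`) gives 52100 nM. Compound 3 (`O=C(CCN1CCN(c2ccc(F)cc2)CC1)c1ccc(C(F)(F)F)cc1`) gives 28500 nM, a number within the scatter of compound 2 and clearly lower than that of compound 1. Compound 4 (`O=C(CCN1CCN(c2ccc(Cl)cc2)CC1)c1ccc(C(F)(F)F)cc1`) has not yet been measured. It differs from compound 3 by chloro in place of fluoro on an aromatic carbon, so that 4-fluorophenyl becomes 4-chlorophenyl. Going by the values given here, no measured step covers this swap. Among the compounds with values here, the only measured step, a 5.8-fold lower number from compound 1 to compound 2 (0.76 log units; beyond the scatter), is bromo in place of methoxy, a different exchange at a different place, so it bears only indirectly and shows that a single swap can move this read-out beyond the scatter. With nothing measured for the swap itself, no shift beyond the scatter is expected in this assay. The expected change is a 1.1-fold lower number from compound 3 to compound 4 (0.06 log units; within the scatter). For compound 4 the estimated value is 25000 nM, with an expected range of 10000 nM to 60000 nM.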

Compound 4, half-maximal inhibitory concentration: 54200 nM
Compound 4: middle estimate off by 2.2-fold (0.34 log units), on the low side; the measured number falls inside the stated range.
By their numbers in this assay, from the lowest: compounds 3, 2 and 4 (each within the scatter of the next); then compound 1.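

In this assay, chloro in place of fluoro on an aromatic carbon, para to a large group, gives a 1.9-fold higher number from compound 3 to compound 4 (0.28 log units; within the scatter) and so stays within the scatter. With 4-chlorophenyl held constant, trifluoromethyl in place of bromo gives a 1.0-fold higher number from compound 2 to compound 4 (0.02 log units; within the scatter) and also stays within the scatter, whereas trifluoromethyl in place of methoxy gives a 5.5-fold lower number from compound 1 to compound 4 (0.74 log units; beyond the scatter) and lies beyond it, so that compound 1 stands apart from both compound 2 and compound 4 at this aromatic carbon. No measurement offered here accounts for these differences.

From the compounds shown here alone, it remains open whether an amine or a carboxylic acid on that aromatic carbon would stand apart as methoxy does. Going by these compounds, the effect of a longer chain joining the carbonyl to the shared core also remains open.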